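Swapping the terminal amide piece on compound 2

A few compounds are considered here, and "the series" means these few. Any claim that something is new, unique, unknown or untested is made for them only; others in the source may bear on it.

Compound 2 `CCOC(=O)C1CCN(C(=O)CN2CN(c3ccccc3)C3(CCN(C(=O)c4ccc(C(C)(C)C)cc4)CC3)C2=O)CC1` gives 3100 nM in an assay on HEK293 cells for displacement of a labelled ligand from NPC1-like intracellular cholesterol transporter 1 (Homo sapiens) (a lower number here means a stronger inhibitor, a higher number a weaker inhibitor), the second highest of the three numbers measured. Compound 1 `CCOC(=O)C1CCN(C(=O)CN2CN(c3ccccc3)C3(CCN(C(=O)c4ccc(C5CCCCC5)cc4)CC3)C2=O)CC1` gives 900 nM, and compound 3 `CC(C)(C)OC(=O)N1CCN(C(=O)CN2CN(c3ccccc3)C3(CCN(C(=O)c4ccc(C5CCCCC5)cc4)CC3)C2=O)CC1` gives 3500 nM, which lies within the scatter of compound 2. Among the measured compounds shown here, the one step measured between neighbours, a 3.4-fold higher number from compound 1 to compound 2 (0.54 log units; beyond the scatter), concerns the aromatic substituent and does not touch the part that changes now. Compound 4 `CC(C)(C)c1ccc(C(=O)N2CCC3(CC2)C(=O)N(CC(=O)N2CCCCC2CCO)CN3c2ccccc2)cc1` differs from compound 2 as follows: 2-(2-hydroxyethyl)piperidin-1-yl in place of 4-(ethoxycarbonyl)piperidin-1-yl on a carbonyl carbon. For the measured compounds named here, no measured step bears directly on this change. Compounds 1 and 3 differ at the same carbonyl carbon, and their values show that a change there can move the number, here towards a higher value. On that basis compound 4 is expected to give a number near 4500 nM in this assay, with a range from 1500 nM to 14000 nM. The expected step of a 1.5-fold higher number from compound 2 to compound 4 (0.16 log units; within the scatter) is therefore a modest rise, but with wide uncertainty.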

Compound 4, half-maximal inhibitory concentration: 6100 nM
The estimate for compound 4 lay 1.4-fold (0.13 log units) below the measured number; measured number inside the range.
By their numbers in this assay, from the lowest: compound 1; then compounds 2, 3 and 4 (each within the scatter of the next).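

In this assay, among the compounds shown here, the step of a 2.0-fold higher number from compound 2 to compound 4 (0.29 log units; within the scatter) gives the first direct reading of a change at this carbonyl carbon with the tert-butyl group held constant. Replacing 4-(ethoxycarbonyl)piperidin-1-yl with 2-(2-hydroxyethyl)piperidin-1-yl, which brings in a hydrogen-bond donor, leaves the number within the scatter, so this pair shows no measurable difference from the exchange. No evidence is available to account for this result. The change moves the ring substituent and replaces it in one step, so the two effects cannot be separated, and 4-(2-hydroxyethyl)piperidin-1-yl or a piperidine bearing a carboxylic acid at the 4-position would be needed to tell them apart. Going by these compounds, it also remains open whether the cyclohexyl group of compound 1 would bring a stronger number when paired with the 2-(2-hydroxyethyl)piperidin-1-yl piece.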